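The source may report more compounds than this note shows. Statements on the series, on what has been measured and on what is new or still open speak of the compounds shown alone.

Within the data shown here, the three compounds measured so far share a dichloroacetamide on an aniline core and differ in the aromatic substituents. Compound 1 `O=C(Nc1cccc(-c2ccsc2)c1)C(Cl)Cl` carries a thiophen-3-yl group. In a functional assay on KB 3-1 cells (Homo sapiens) for cytotoxicity, read by MTT assay, with a stated time of 68 h (on this read-out higher numbers stand for weaker inhibition and lower numbers for stronger inhibition), compound 1 gives > 50000 nM, which is a limit of the assay rather than a number. Compound 2 `CC(C)Oc1ccc(-c2cc(NC(=O)C(Cl)Cl)cc(-c3ccc(OC(C)C)cc3)c2)cc1` gives 8850 nM in this assay. Compound 3 `COc1ccccc1-c1cc(NC(=O)C(Cl)Cl)cc(-c2ccccc2OC)c1` gives > 30000 nM in this assay, again a limit and not a number. Compound 1 therefore stands at the limit of > 50000 nM in this assay, at which 1 of the 3 values shown sits. Compound 3 stands at the limit of > 30000 nM in this assay, at which 1 of the 3 values shown sits.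

Compound 4 `O=C(Nc1cccc(-c2ccccc2)c1)C(Cl)Cl` has not yet been measured in this assay. It differs from compound 1 in one place: phenyl in place of thiophen-3-yl on an aromatic carbon. Among the measured compounds shown here, no measured pair differs in this way, so the size of the step cannot be read from a measured step and can only be expected. The step from compound 1 to compound 4 is expected to be a step that the limit leaves unreadable from compound 1 to compound 4, that is, no change beyond the scatter. Compound 4 is estimated to give about 60000 nM in this assay, with a range from 20000 nM to 200000 nM, and most likely the assay would again report only a limit.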

Compound 4, half-maximal inhibitory concentration: 46800 nM
Compound 4: the middle estimate sits 1.3-fold (0.11 log units) above what was measured; measured number inside the range.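

Compound 4 gives this position a measured number rather than a limit: in this assay compound 4 gives 46800 nM. Phenyl in place of thiophen-3-yl on an aromatic carbon amounts to an at least 1.0-fold lower number from compound 1 to compound 4 (0.02 log units; that floor lies within the scatter), so the change can be read only as a floor, and the two compounds do not show that exchanging these rings makes a real difference. That floor rests on a limit of the assay for compound 1: the limit of > 50000 nM in this assay, at which 1 of the 4 values shown sits.

The compounds shown leave open how large the step from thiophen-3-yl to phenyl really is, since it has no readable upper size. They also leave open whether an amine or a carboxylic acid in this place, instead of either ring, would give a number clearly apart from that of compound 4.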